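Removing the methylsulfonyl group from compound 2

The source may hold more compounds than are shown below. What is called first, only, known or untested is meant among the compounds shown, and "the series" means these compounds.

Of the compounds shown here, two with a shared core have numbers so far. In a physicochemical assay for solubility, read by HPLC, using the shake flask method, measured as kinetic solubility, with a stated time of 20 h, at pH 6.5, tested at 200 uM (on this read-out higher numbers stand for higher solubility and lower numbers for lower solubility), compound 1 (`C[C@@H](CO)NS(=O)(=O)c1cccc(-c2ccc3nccc(-c4ccncc4)c3n2)c1`) gives 50000 nM and compound 2 (`CS(=O)(=O)Nc1cccc(-c2ccc3nccc(-c4ccncc4)c3n2)c1`) gives 20000 nM as the lower of the two numbers. Compound 3 (`Nc1cccc(-c2ccc3nccc(-c4ccncc4)c3n2)c1`) has not yet been measured. It differs from compound 2 by a single change, hydrogen in place of methylsulfonyl on a nitrogen on an aromatic ring, which turns methanesulfonamido into amino (hydrogen in place of methylsulfonyl on a nitrogen on an aromatic ring). Within the data shown here, only one measured step bears on this, namely a 2.5-fold lower number from compound 1 to compound 2 (0.40 log units; beyond the scatter) and it was modest. That step exchanged a different pair of groups, so it is only a loose guide, and no measurement here shows the removal of methylsulfonyl itself. One step sets no rule, but a modest step in the same downward direction is expected in this assay for now. The expected change is a 2.2-fold lower number from compound 2 to compound 3 (0.35 log units; beyond the scatter) as an estimate only. For compound 3 the estimated solubility is 9000 nM with an expected range from 2500 nM to 30000 nM around that middle.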

Compound 3, solubility: < 5000 nM
Compound 3: no number, only a limit (the forecaster's own chance of this, stated with the estimate: 5%); at least 1.8-fold (0.25 log units) between middle value and limit.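

In this assay compound 3 has no exact number, only a limit of the assay: the limit of < 5000 nM in this assay, at which 1 of the 3 values shown sits.

Even so, the step can be read as a bound. Taking methylsulfonyl off the nitrogen on the aromatic ring, which leaves a plain amino, gives an at least 4.0-fold lower number from compound 2 to compound 3 (0.60 log units; beyond the scatter), and the comparison with the other measured compound gives an at least 10-fold lower number from compound 1 to compound 3 (1.00 log units; beyond the scatter). Among these compounds, until now the only comparison was between two sulfonyl-containing groups, methanesulfonamido and (1-(hydroxymethyl)ethyl)sulfamoyl; now the three compounds fall in a clear order, with each step beyond the scatter and the plain amino of compound 3 at the bottom, so the number at this position clearly depends on what the nitrogen carries.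

As far as these compounds go, the full size of the drop stays open, since a limit marks only where the read-out ends and the true number for compound 3 could lie well past it. Also open, from the compounds shown here alone, is whether an acetyl group on the same nitrogen, or a carboxylic acid or a longer chain ending in a hydroxyl in place of the amino, would read closer to compound 2 or to compound 3.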